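A few compounds are considered here, and "the series" means these few. Any claim that something is new, unique, unknown or untested is made for them only; others in the source may bear on it.

Working notes on the series.

Compound 1 `COc1ccc(-c2cc(/C=C/C(=O)c3ccc(N)cc3)[nH]n2)cc1` and compound 3 `COc1ccc(-c2cc(/C=C/C(=O)c3ccc(N)cc3)[nH]n2)cc1OC` share one core and differ in a single place. In a functional assay on UO-31 cells (Homo sapiens) for cytotoxicity, read by sulforhodamine B assay, with a stated time of 48 h, tested at 100 uM (on this read-out higher numbers stand for a weaker effect at the one concentration tested and lower numbers for a stronger effect), compound 1 gives -87% and compound 3 gives -85%. The change methoxy in place of hydrogen on an aromatic carbon made a step of a number 2 percentage points higher from compound 1 to compound 3 (within the scatter). Compound 2 `COc1ccc(C(=O)/C=C/c2cc(-c3cc(OC)c(OC)c(OC)c3)n[nH]2)cc1OC` rests on another core; how the two cores differ is not broken down here. In this assay compound 2 gives -96%, a value within the scatter of compound 1 and beyond the scatter from compound 3, so nothing firm separates compound 2 from compound 1.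

Compound 4 `COc1cc(C(=O)/C=C/c2cc(-c3cc(OC)c(OC)c(OC)c3)n[nH]2)cc(OC)c1OC` has not yet been measured. Among the compounds with values here, it differs from compound 2 by methoxy in place of hydrogen on an aromatic carbon, the same kind of change as the one from compound 1 to compound 3, though not the same: around the place in compound 4 the entering methoxy is also meta to a methoxy group, which the place in compound 3 is not. Within the data shown here, only one measured pair carries this change. Resting on the step of a number 2 percentage points higher from compound 1 to compound 3 (within the scatter), which was within the scatter, a step of a number 2 percentage points higher from compound 2 to compound 4 (within the scatter) is expected in this assay. Compound 4 is therefore estimated to give -94% in this assay, with a range expected from -106% to -80%.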

Compound 4, a percentage reported as activity, at one concentration (the size of the read-out at that concentration, not a potency): -100%
Compound 4: middle estimate off by 6 percentage points, on the high side; the range from low to high includes it.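

In this assay methoxy in place of hydrogen on an aromatic carbon gives a step of a number 4 percentage points lower from compound 2 to compound 4 (within the scatter). Set beside the earlier step, this shows that the change carries from one core to the other without a detectable difference, since neither step nor the gap between them lies beyond the scatter: the same change on two cores in this assay, a number 2 percentage points higher (within the scatter) from compound 1 to compound 3 and a number 4 percentage points lower (within the scatter) from compound 2 to compound 4, 6 percentage points apart, within the scatter of two such steps

Within the data shown here, this agreement rests on only two pairs, neither of which shows a firm effect of the change, so it supports no more than the absence of a measurable step on these two cores; it gives no size for the change and cannot separate any influence of the surroundings of the place, which in compound 4 is also meta to a methoxy group. The read-out comes from a single concentration. It says nothing of potency.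

As far as these compounds go, what a hydroxyl group, a fluorine atom, a carboxylic acid or a longer chain such as ethoxy would do at this place remains open. Also open, from the compounds shown here alone, is whether the same change would give a step beyond the scatter on any other core or at a lower concentration.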